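The source may report more compounds than this note shows. Statements on the series, on what has been measured and on what is new or still open speak of the compounds shown alone.

Compound 1 `Cc1ccccc1-n1nc(-c2ccccc2)nc1CNc1ccc(C(=O)NO)cc1` was tested in an assay on Sf9 cells for inhibition of protein deacetylase HDAC6 (Homo sapiens), read by fluorescence, with a stated time of 40 min, tested at 100 nM (a higher number here means more inhibition at the concentration tested (going by the name of the read-out), a lower number less inhibition), where compound 1 gives 57.1%. Among the compounds with values here, compound 2 `O=C(NO)c1ccc(NCc2nc(-c3ccco3)nn2-c2ccccc2)cc1` gives 59.9% in this assay, so the two numbers cannot be told apart within the scatter, and compound 1 stands level with the only other measured compound. Compound 3 `O=C(NO)c1ccc(NCc2nc(-c3ccccc3)nn2-c2cccc(Cl)c2)cc1` differs from compound 1 in one place: 3-chlorophenyl in place of 2-methylphenyl on an aromatic nitrogen. Within the data shown here, no step between measured compounds shows how this change acts, so the expectation rests on the two values at hand alone. The expected step is a number 1.1 percentage points lower from compound 1 to compound 3 (within the scatter), no larger than the scatter in either direction. Compound 3 is therefore estimated at 56%, between 38% and 74%.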

Compound 3, a percentage reported as inhibition, at one concentration (the size of the read-out at that concentration, not a potency): 62.3%
Beside the measured number, compound 3's estimate is 6.3 percentage points below it, within the range that was stated.
By their numbers in this assay, from the lowest: compounds 1, 2 and 3 (each within the scatter of the next).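

Putting 3-chlorophenyl in place of 2-methylphenyl on the aromatic nitrogen gives a number 5.2 percentage points higher from compound 1 to compound 3 (within the scatter) in this assay. Within the data shown here, this is the first step read at this position, and it shows that these two substituted phenyl groups cannot be told apart here. Nothing measured here bears on why the two groups read alike. As far as these compounds go, whether a carboxylic acid or an amine on that phenyl ring, or a longer alkyl chain in its place on the aromatic nitrogen, would move the number beyond the scatter remains open.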